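Fluoro on the Pendant Phenyl, Carried to a Second Core

This account rests on a few compounds, and the source may have more. Where it says the series, first, only, none or still open, it means among the compounds named here.

Compound 1 `O=C(Nc1nnc(-c2ccccc2)s1)c1cc(Cl)ccc1O` and compound 2 `O=C(Nc1nnc(-c2ccc(F)cc2)s1)c1cc(Cl)ccc1O` share one core; compound 3 `O=C(Nc1nnc(-c2ccccc2)s1)c1ccccc1` and the unmeasured compound 4 `O=C(Nc1nnc(-c2ccc(F)cc2)s1)c1ccccc1` share another. The difference between the two cores is not broken down here. In a functional assay on B16-F10 cells (Mus musculus) for antiproliferative activity, read by MTT assay, with a stated time of 48 h (on this read-out higher numbers stand for weaker inhibition and lower numbers for stronger inhibition), compound 1 gives 1140 nM and compound 2 gives 680 nM; the change fluoro in place of hydrogen on an aromatic carbon made a 1.7-fold lower number from compound 1 to compound 2 (0.22 log units; within the scatter). In this assay compound 3 gives 5150 nM, the highest number among the three measured compounds. Compound 4 carries the same change, (fluoro in place of hydrogen on an aromatic carbon), on the other core. Going by the values given here, the step from compound 3 to compound 4 is expected to be a 1.5-fold lower number from compound 3 to compound 4 (0.17 log units; within the scatter), resting on the single measured step of a 1.7-fold lower number from compound 1 to compound 2 (0.22 log units; within the scatter), which was itself within the scatter. On that basis compound 4 is estimated at 3500 nM, between 1500 nM and 8000 nM.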

Compound 4, half-maximal inhibitory concentration: 4750 nM
Compound 4: the middle estimate sits 1.4-fold (0.13 log units) below what was measured; low and high end bracket the measured number.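

In this assay, phenyl to 4-fluorophenyl on the second core gives a 1.1-fold lower number from compound 3 to compound 4 (0.04 log units; within the scatter), so on neither core does the change move the number beyond the scatter. Set beside the earlier step, the change reads alike on the two cores: the same change on two cores in this assay, a 1.7-fold lower number (0.22 log units; within the scatter) from compound 1 to compound 2 and a 1.1-fold lower number (0.04 log units; within the scatter) from compound 3 to compound 4, 1.5-fold (0.19 log units) apart, within the scatter of two such steps This shows that a small step carried over between these two pairs of compounds; it does not show that fluoro has a real effect on either core, and two pairs cannot establish a rule for the series.

Still open, going by these compounds, is whether a methoxy group, an amine or a carboxylic acid on that same aromatic carbon would give a step beyond the scatter. Also open, on these data alone, is how fluoro behaves on any other core.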